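This account rests on a few compounds, and the source may have more. Where it says the series, first, only, none or still open, it means among the compounds named here.

Measured so far in a functional assay on MDA-MB-231 cells (Homo sapiens) for cytotoxicity, read by MTT assay, with a stated time of 72 h, tested at 1 uM, in the absence of a further agent; a higher number here means a weaker effect of the compound at the concentration tested, a lower number a stronger effect:
Compound 1 `CC1(C)CC(=S)Nc2ccc(Cl)cc21` gives 85.7%.
Compound 2 `CNC1=Nc2ccc(Cl)cc2C(C)(C)C1` gives 91.9%.

Compound 2 stands alongside compound 1; the two values lie within the usual scatter of each other, so the numbers shown do not set one apart from the other. Compound 3 `CC1(C)CC(NCCCCO)=Nc2ccc(Cl)cc21` has not yet been measured in this assay. It differs from compound 2 by 3-hydroxypropyl in place of hydrogen on a saturated chain carbon bound to an amine nitrogen. Within the data shown here, no step between measured compounds touches this position, so nothing anchors the size of the change. The expected step is a number 1.9 percentage points lower from compound 2 to compound 3 (within the scatter), none beyond the scatter in either direction. Compound 3 is therefore estimated at 90%, with a range from 76% to 100%.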

Compound 3, a percentage reported as activity, at one concentration (the size of the read-out at that concentration, not a potency): 87.6%
Compound 3: middle estimate off by 2.4 percentage points, on the high side; the range from low to high includes it.
By their numbers in this assay, from the lowest: compounds 1, 3 and 2 (each within the scatter of the next).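

In this assay, 3-hydroxypropyl in place of hydrogen on a saturated chain carbon bound to an amine nitrogen gives the first step read at this position, a number 4.3 percentage points lower from compound 2 to compound 3 (within the scatter), so going from methylamino to (4-hydroxybutyl)amino does not set the two compounds apart. This position therefore carries the added chain without a change beyond the scatter at the single concentration tested. No measured evidence bears on this result.

Still open, as far as these compounds go, is whether a carboxylic acid or an amine at the end of the chain, or a longer chain, would move the number beyond the scatter. From the compounds shown here alone, a piperidine ring on the same nitrogen is equally open.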